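Restoring a carbonyl on the nitrogen of compound 2

A few compounds are considered here, and "the series" means these few. Any claim that something is new, unique, unknown or untested is made for them only; others in the source may bear on it.

Measured in a functional assay on KB cells (Homo sapiens) for cytotoxicity; on this read-out higher numbers stand for weaker inhibition and lower numbers for stronger inhibition:
- Compound 1 `COc1ccc(S(=O)(=O)N2CCc3cccc(NC(=O)c4ccncc4)c32)cc1`: 8.9 nM
- Compound 2 `COc1ccc(S(=O)(=O)N2CCc3cccc(NCc4ccccc4)c32)cc1`: > 10000 nM (a limit)

Compound 2 gives > 10000 nM, which is a limit of the assay and not a number, as the limit of > 10000 nM in this assay, at which 1 of the 2 values shown sits, shows.

Compound 3 `COc1ccc(S(=O)(=O)N2CCc3cccc(NC(=O)c4ccccc4)c32)cc1` carries benzoyl in place of benzyl on a nitrogen on an aromatic ring. Among the compounds with values here, one measured step bears on this change, and it is large: an at least 1100-fold higher number from compound 1 to compound 2 (3.05 log units; beyond the scatter). That step put benzyl in place of (pyridin-4-yl)carbonyl. Compound 3 has a carbonyl there again, but with a ring of carbon only, so a full return to the level of compound 1 at 8.9 nM is not assumed. A large fall in this assay is expected, estimated as an at least 160-fold lower number from compound 2 to compound 3 (2.22 log units; beyond the scatter). The expected value for compound 3 is 60 nM, with an estimated range of 8 nM to 1000 nM.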

Compound 3, half-maximal inhibitory concentration: 180 nM
Compound 3: the middle estimate sits 3.0-fold (0.48 log units) below what was measured; measured number inside the range.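

In this assay, benzoyl in place of benzyl on this nitrogen gives an at least 55-fold lower number from compound 2 to compound 3 (1.74 log units; beyond the scatter), so a carbonyl here matters even without the pyridin-4-yl ring. The value of compound 2 is a limit and not a number: the limit of > 10000 nM in this assay, at which 1 of the 3 values shown sits.

The ring on the carbonyl counts as well, since phenyl in place of pyridin-4-yl on the carbonyl carbon gives a 20-fold higher number from compound 1 to compound 3 (1.31 log units; beyond the scatter).

Still open, as far as these compounds go, is how the number would move with a methyl group or a piperidine ring on the carbonyl carbon. Also open, from the compounds shown here alone, is whether a sulfonyl linker could stand in for the carbonyl.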